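Swapping cyano for methyl on the shared core

A few compounds are considered here, and "the series" means these few. Any claim that something is new, unique, unknown or untested is made for them only; others in the source may bear on it.

- Compound 1 (`CC(=O)N[C@@H]1CCC[C@H](C(=O)Nc2cc(-c3cnn4c3CC(C)(C)C4)c(F)cn2)C1`): 19 mL.min-1.g-1
- Compound 2 (`CC(=O)N[C@@H]1CCC[C@H](C(=O)Nc2cc(-c3cnn4c3CC(C)(C)C4)c(C#N)cn2)C1`): 26 mL.min-1.g-1

In an ADME assay on microsomes from liver (Homo sapiens) for metabolic stability (on this read-out higher numbers stand for fast clearance and lower numbers for slow clearance), compound 2 stands at 26 mL.min-1.g-1 and cannot be told apart from compound 1 at 19 mL.min-1.g-1 on these numbers. Compound 3 (`CC(=O)N[C@@H]1CCC[C@H](C(=O)Nc2cc(-c3cnn4c3CC(C)(C)C4)c(C)cn2)C1`) differs from compound 2 by methyl in place of cyano on an aromatic carbon. Going by the values given here, only one measured step bears on this, at the same carbon: cyano in place of fluoro gave a 1.4-fold higher number from compound 1 to compound 2 (0.14 log units; within the scatter) and so stayed within the scatter. Among the compounds with values here, one step is a thin guide, and no measured compound carries methyl there. No shift beyond the scatter is therefore expected, and no firm direction. The estimated change is a 1.0-fold lower number from compound 2 to compound 3 (0.02 log units; within the scatter) and nothing larger is expected. For compound 3 the estimated value in this assay is 25 mL.min-1.g-1 (expected range 12 mL.min-1.g-1 to 50 mL.min-1.g-1).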

Compound 3, intrinsic clearance in microsomes in the Homo sapiens assay: 19 mL.min-1.g-1
Beside the measured number, compound 3's estimate is 1.3-fold (0.12 log units) above it, and the stated range covers the measured number.
By their numbers in the Homo sapiens assay, from the lowest: compounds 1, 3 and 2 (each within the scatter of the next).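

In the Homo sapiens assay, compound 1 gives 19 mL.min-1.g-1, compound 2 gives 26 mL.min-1.g-1 and compound 3 gives 19 mL.min-1.g-1. In the Homo sapiens assay, methyl on this aromatic carbon gives a 1.4-fold lower number from compound 2 to compound 3 (0.14 log units; within the scatter) and no change at the digits printed from compound 1 to compound 3 (within the scatter), so fluoro, cyano and methyl all lie within the scatter of one another at this position. In a physicochemical assay for lipophilicity, using the shake flask method, measured as octanol-water partition, at pH 7.4 (on this read-out lower numbers stand for lower lipophilicity and higher numbers for higher lipophilicity), compound 2 gives 3.2 and compound 3 gives 3.1. In the physicochemical assay, the change gives a number 0.10 log units lower from compound 2 to compound 3 (within the scatter), so neither read-out separates the two compounds, even though the cyano that leaves has a triple bond and a hydrogen-bond acceptor and the methyl that enters has neither. No supporting information is available to explain why these numbers stay so close.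

As far as these compounds go, whether an amine or a carboxylic acid on this aromatic carbon would move either read-out beyond the scatter remains open. Going by these compounds alone, it is also unknown whether the same swaps would behave alike on a core other than the one these three compounds share.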